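The compounds below may be only part of what the source reports. "The series", "measured", "known", "first", "only" and "open" are said of these compounds alone.

Measured compounds:
compound 1, `O=C(CSc1nc(Nc2ccccc2)c2ccccc2n1)Nc1cccc(Cl)c1`, which in a functional assay on PC-3 cells (Homo sapiens) for inhibition, read by MTT assay, with a stated time of 72 h (a lower number here means a stronger inhibitor, a higher number a weaker inhibitor), gives 12600 nM
compound 2, `O=C(CSc1nc(Nc2ccccc2)c2ccccc2n1)Nc1ccc([N+](=O)[O-])cc1`, which in this assay gives 25000 nM

For the measured compounds named here, of these two numbers, the one for compound 2 is the larger, but the step of a 2.0-fold higher number from compound 1 to compound 2 (0.30 log units; within the scatter) lies within the scatter, so compound 1 and compound 2 cannot be told apart on these data. Compound 3, `O=C(CSc1nc(Nc2ccccc2)c2ccccc2n1)Nc1ccc(Cl)cc1Cl`, differs from compound 2 by 2,4-dichlorophenyl in place of 4-nitrophenyl on an amide-type nitrogen. Going by the values given here, the only measured step that bears on a change of the group on this amide-type nitrogen is a 2.0-fold higher number from compound 1 to compound 2 (0.30 log units; within the scatter), and it stayed within the scatter; no other step at this position has been measured. On that basis the expected step of a 1.6-fold lower number from compound 2 to compound 3 (0.19 log units; within the scatter) is none beyond the scatter, and its direction cannot be called. Compound 3 is therefore estimated at 16000 nM in this assay, with a range from 5000 nM to 60000 nM.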

Compound 3, half-maximal inhibitory concentration: 9110 nM
The estimate for compound 3 lay 1.8-fold (0.24 log units) above the measured number; low and high end bracket the measured number.
By their numbers in this assay, from the lowest: compounds 3, 1 and 2 (each within the scatter of the next, the first and the last beyond it).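

For the compounds shown here, at the amide-type nitrogen, 2,4-dichlorophenyl in place of 4-nitrophenyl gives a 2.7-fold lower number from compound 2 to compound 3 (0.44 log units; beyond the scatter) in this assay and is the first step at this position to pass the scatter, though only modestly. By contrast, the step of a 1.4-fold lower number from compound 1 to compound 3 (0.14 log units; within the scatter) stays within the scatter, so 3-chlorophenyl and 2,4-dichlorophenyl cannot be told apart here, and of the three compounds only compound 2 and compound 3 are separated. Nothing available accounts for this difference.

The compounds shown carry only substituted phenyl groups on this nitrogen, so it remains open how an unsubstituted phenyl, a cyclohexyl ring or a chain ending in an amine would read in this assay at this position. Also open, from the compounds shown here alone, is whether a methoxy group or a carboxylic acid elsewhere on the shared core would shift these numbers.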